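This account rests on a few compounds, and the source may have more. Where it says the series, first, only, none or still open, it means among the compounds named here.

Measured so far in a functional assay (Cavia porcellus) with sulfonylurea receptors; K-ATP channels (Homo sapiens) as the target; a higher number here means a weaker inhibitor, a lower number a stronger inhibitor:
compound 1, `CC(O)(C(=O)Nc1ccc(S(=O)(=O)c2cccc(F)c2)cc1)C(F)(F)F`, gives 3400 nM
compound 2, `COc1ccc(S(=O)(=O)c2ccc(NC(=O)C(C)(O)C(F)(F)F)cc2)cc1`, gives > 30000 nM

Compound 2 sits at the weaker end of the two numbers shown. Its value in this assay is a limit of the assay, not a measured number. Among the measured compounds shown here, the one measured step, an at least 8.8-fold higher number from compound 1 to compound 2 (0.94 log units; beyond the scatter), is therefore known only as a bound because of the limit of > 30000 nM in this assay, at which 1 of the 2 values shown sits.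

Compound 3, `CC(O)(C(=O)Nc1ccc(S(=O)(=O)c2cccnc2)cc1)C(F)(F)F`, is not yet measured in this assay. It differs from compound 2 by pyridin-3-yl in place of 4-methoxyphenyl on a sulfonyl sulfur. For the measured compounds named here, no measured step involves pyridin-3-yl, so the only step that bears on this change is an at least 8.8-fold higher number from compound 1 to compound 2 (0.94 log units; beyond the scatter): it shows that the group on the sulfonyl sulfur moves the number beyond the scatter, and that 4-methoxyphenyl gives a limit. Pyridin-3-yl is neither of the two groups measured, so the direction rests on that single step alone.

Compound 3 is expected at 15000 nM, with a range of 4000 nM to 40000 nM. The expected step is an at least 2.0-fold lower number from compound 2 to compound 3 (0.30 log units; that floor lies within the scatter), a move that cannot be sized against a limit; a value again beyond the limit remains possible.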

Compound 3, half-maximal inhibitory concentration: 3500 nM
Beside the measured number, compound 3's estimate is 4.3-fold (0.63 log units) above it; the measured number lies below the stated range.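

In this assay, the group on the sulfonyl sulfur now has a third reading, and replacing 4-methoxyphenyl with a second, different group again gives a clear shift, an at least 8.5-fold lower number from compound 2 to compound 3 (0.93 log units; beyond the scatter), so the result with compound 1 no longer stands alone. Pyridin-3-yl and 3-fluorophenyl cannot be told apart at this position, with a 1.0-fold higher number from compound 1 to compound 3 (0.01 log units; within the scatter), so a six-membered aromatic ring with one hetero atom and a fluorine-bearing carbon-only ring give matching readings, and among the three groups only 4-methoxyphenyl stands apart. The shift from 4-methoxyphenyl remains a bound and not a sized change, because compound 2 carries a limit of the assay and not a number: the limit of > 30000 nM in this assay, at which 1 of the 3 values shown sits.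

The compounds shown leave open whether the limit seen with compound 2 belongs to the methoxy group or to the carbon-only ring that carries it, a question on which an unsubstituted phenyl on the sulfonyl sulfur would bear. Also open, as far as these compounds go, is whether any group at this position, such as an amine-bearing ring or a carboxylic acid-bearing ring, moves the number clearly away from the readings shared by compound 1 and compound 3.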